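Swapping the Benzyl Arm for a Plain Phenyl

The source may hold more compounds than are shown below. What is called first, only, known or untested is meant among the compounds shown, and "the series" means these compounds.

The study centres on a shared core carried by compound 1 `CCOC(=O)c1ccc(-c2nn(Cc3ccccc3OC)c3ccccc23)cc1`, which bears an ethyl ester and a 2-methoxybenzyl group on an aromatic nitrogen of a five-membered aromatic ring with two nitrogens within a fused system of two rings. Among the compounds with values here, in a functional assay on cells (Platelet, Homo sapiens) for inhibition (on this read-out higher numbers stand for weaker inhibition and lower numbers for stronger inhibition), compound 1 gives 470 nM, the only numerical value reported in this set. The companion compound 2 `O=C(O)c1ccc(-c2nn(Cc3ccccc3)c3ccccc23)cc1`, in which the ester has become a free acid and the arm is a simple benzyl, is reported in this assay only as a limit, compound 2 standing at > 10000 nM; this limit of > 10000 nM in this assay, at which 1 of the 2 values shown sits, is where one of the two values sits. Within the data shown here, no step between measured compounds can be drawn from these two, since they differ in two places at once.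

Compound 3 `CCOC(=O)c1ccc(-c2nn(-c3ccccc3)c3ccccc23)cc1` has yet to be measured in this assay. It differs from compound 1 in one place: phenyl in place of 2-methoxybenzyl on an aromatic nitrogen. The ester of compound 1 is kept, so compound 3 is expected to remain a measurable inhibitor, though a modest loss is estimated, with the expected step of a 3.2-fold higher number from compound 1 to compound 3 (0.50 log units; beyond the scatter) falling somewhat beyond the scatter. Compound 3 is therefore estimated at 1500 nM, with a range from 300 nM to 8000 nM.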

Compound 3, half-maximal inhibitory concentration: 2640 nM
Beside the measured number, compound 3's estimate is 1.8-fold (0.25 log units) below it; the measured number falls inside the stated range.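

In this assay, the group on the aromatic nitrogen now has its first readable step, with the ethyl ester kept on both sides: a 5.6-fold higher number from compound 1 to compound 3 (0.75 log units; beyond the scatter). The change from 2-methoxybenzyl to phenyl therefore weakens inhibition without removing it, and compound 3 still gives a measured number, 2640 nM, rather than a limit. No measured property shown here accounts for this step.

The swap removes the methoxy group and shortens the arm in a single change, so the compounds shown leave open how much of the loss belongs to each, a question that a plain benzyl arm carrying the ethyl ester, or a 2-methoxyphenyl arm, would help to separate. Also open, going by these compounds, is how a longer chain such as 2-phenylethyl on the aromatic nitrogen would read, and how an amide in place of the ethyl ester would compare with a one-place change on the same arm.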